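The source may report more compounds than this note shows. Statements on the series, on what has been measured and on what is new or still open speak of the compounds shown alone.

Working notes on the series. In a functional assay on cells (Cancer cell lines, Homo sapiens) for cytotoxicity, read by sulforhodamine B assay, with a stated time of 48 h (on this read-out higher numbers stand for weaker inhibition of growth and lower numbers for stronger inhibition of growth), compound 1 `NS(=O)(=O)c1ccc(-n2nc(-c3ccc(Cl)cc3)cc2-c2cc(O)ccc2O)cc1` gives 54500 nM, and compound 2 `Cc1ccc(-c2cc(C3=CC(=O)C=CC3=O)n(-c3ccc(S(N)(=O)=O)cc3)n2)cc1` gives 95500 nM; the two numbers lie within the scatter of each other, so no order between them can be read from this assay. Compound 3 `NS(=O)(=O)c1ccc(-n2nc(-c3ccc(Cl)cc3)cc2C2=CC(=O)C=CC2=O)cc1` is not yet measured. It differs from compound 2 by chloro in place of methyl on an aromatic carbon. Going by the values given here, no step between measured compounds isolates this change, and compound 1 already carries the chloro group with a different partner ring. Nothing in the pair suggests movement beyond the scatter, so the step from a 1.4-fold lower number from compound 2 to compound 3 (0.13 log units; within the scatter) is expected to be small. Compound 3 is therefore estimated at 70000 nM, in the range 30000 nM to 160000 nM.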

Compound 3, concentration for total growth inhibition: 62600 nM
Estimate against measurement, compound 3: 1.1-fold (0.05 log units) above, within the range that was stated.
By their numbers in this assay, from the lowest: compounds 1, 3 and 2 (each within the scatter of the next).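

In this assay, the change from 4-methylphenyl to 4-chlorophenyl gives a 1.5-fold lower number from compound 2 to compound 3 (0.18 log units; within the scatter), so this position shows no readable difference between methyl and chloro. With chloro held constant, the six-membered non-aromatic ring in place of the six-membered aromatic ring gives a 1.1-fold higher number from compound 1 to compound 3 (0.06 log units; within the scatter), so this exchange also leaves no readable difference. No supporting data bear on either result.
Going by these compounds, whether an amine or a carboxylic acid on that aromatic carbon would give a value beyond the scatter stays open. Also open, on these data alone, is whether either ring exchange would read differently with a methoxy group in place of chloro.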